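The compounds below may be only part of what the source reports. "The series", "measured", "known", "first", "only" and "open" are said of these compounds alone.

Measured so far:
compound 1 `CC1=Cc2c(cc(C)oc2=O)OC1c1ccco1` — 64.3%
compound 2 `Cc1cc2c(c(=O)o1)C=C(C(C)C)C(CC(C)C)O2` — 96.6%

In a functional assay on SH-SY5Y cells (Homo sapiens) for antiproliferative activity, with a stated time of 24 h, tested at 25 ug/mL (a higher number here means a stronger effect of the compound at the concentration tested, a lower number a weaker effect), compound 2 gives 96.6%, the highest of the two numbers shown; the nearest number, that of compound 1, lies lower by a margin beyond the usual scatter. Compound 3 `Cc1cc2c(c(=O)o1)C=C(c1ccccc1)C(CC(C)C)O2` has not yet been measured. It differs from compound 2 in one place: phenyl in place of isopropyl on a double-bonded ring carbon. Among the compounds with values here, no step between two measured compounds isolates a change of this kind, since compound 1 and compound 2 differ at several places at once and their gap cannot be read as a single step. The number for compound 2 already sits near the top of the read-out scale, so little room remains upward. The step of a number 11.6 percentage points lower from compound 2 to compound 3 (beyond the scatter) is expected to be modest and downward, or none beyond the scatter. Compound 3 is therefore estimated at 85%, within 60% to 100%.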

Compound 3, a percentage reported as inhibition, at one concentration (the size of the read-out at that concentration, not a potency): 45.7%
Compound 3: middle estimate off by 39.3 percentage points, on the high side, and the stated range ends above it.
By their numbers in this assay, from the lowest: compound 3; then compound 1; then compound 2.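

In this assay, the double-bonded ring carbon two ring bonds from the ring oxygen proves sensitive to the group it carries: phenyl in place of isopropyl gives a number 50.9 percentage points lower from compound 2 to compound 3 (beyond the scatter). Within the data shown here, this is the first step that isolates a single place, and it shows that activity at the tested concentration depends strongly on this position, although one replacement gives no trend. Nothing measured here accounts for the fall in the number.

The compounds shown leave open whether the aromatic ring or simply the larger number of heavy atoms goes with the lower number, a question that a cyclohexyl group at this carbon could help to separate. Also open, on these data alone, is how a smaller methyl group, or a phenyl ring carrying an amine, would read at this position.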